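The source may hold more compounds than are shown below. What is called first, only, known or untested is meant among the compounds shown, and "the series" means these compounds.

Measured so far in an ADME assay on microsomes from liver (Rattus norvegicus) for metabolic stability; a higher number here means faster removal of the compound, a lower number slower removal:
- compound 1 `CCC(Oc1ccc(-n2cc(C(F)(F)F)cn2)cc1)c1ccc(C(=O)NCCC(=O)O)cc1`: < 25 mL/min/kg
- compound 2 `O=C(O)CCNC(=O)c1ccc(C(Oc2ccc(-n3cc(C(F)(F)F)cn3)cc2)C2CCCC2)cc1`: 31 mL/min/kg
- compound 3 `CC(C)(C)C(Oc1ccc(-n2cc(C(F)(F)F)cn2)cc1)c1ccc(C(=O)NCCC(=O)O)cc1`: 28 mL/min/kg

Compound 1 sits at the limit of this assay, (the limit of < 25 mL/min/kg in this assay, at which 1 of the 3 values shown sits); its value is a limit and not a number, so its standing is known only as a bound. Compound 2 gives 31 mL/min/kg in this assay. Compound 3 gives 28 mL/min/kg in this assay. Both measured steps enlarge the group on the saturated chain carbon bound to an aromatic carbon and an oxygen on an aromatic ring: an at least 1.2-fold higher number from compound 1 to compound 2 (0.09 log units; that floor lies within the scatter) and an at least 1.1-fold higher number from compound 1 to compound 3 (0.04 log units; that floor lies within the scatter), each a floor that lies within the scatter, and between them a 1.1-fold lower number from compound 2 to compound 3 (0.04 log units; within the scatter), also within the scatter.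

Compound 4 `CC(C)CC(Oc1ccc(-n2cc(C(F)(F)F)cn2)cc1)c1ccc(C(=O)NCCC(=O)O)cc1` carries the change (isopropyl in place of methyl on a saturated chain carbon, two bonds along the chain from an aromatic carbon and an oxygen on an aromatic ring); cut one bond further out, this reads ethyl to isobutyl, so it is of the same kind as the two measured steps, a larger saturated group at that position. Those steps give no movement beyond the scatter, so the expected step of an at least 1.2-fold higher number from compound 1 to compound 4 (0.07 log units; that floor lies within the scatter) is small and upward at most. Compound 4 is estimated at 30 mL/min/kg, within 15 mL/min/kg to 60 mL/min/kg.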

Compound 4, clearance: 46 mL/min/kg
Compound 4: the middle estimate sits 1.5-fold (0.19 log units) below what was measured; the range from low to high includes it.
By their numbers in this assay, from the lowest: compounds 3, 2 and 4 (each within the scatter of the next). At a limit, below all of these: compound 1.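

In this assay, ethyl to isobutyl gives an at least 1.8-fold higher number from compound 1 to compound 4 (0.26 log units; that floor lies within the scatter) and is the largest floor printed so far at this position, yet it still does not leave the scatter. Isobutyl in place of tert-butyl gives a 1.6-fold higher number from compound 3 to compound 4 (0.22 log units; within the scatter) and isobutyl in place of cyclopentyl gives a 1.5-fold higher number from compound 2 to compound 4 (0.17 log units; within the scatter), so neither step separates isobutyl from the other two groups. The wider spread of values across these larger saturated groups therefore shows no dependence on their shape that can be read from this assay.

Still open, as far as these compounds go, is whether an amine or a longer chain ending in a hydroxyl group at this position would move the number beyond the scatter. Compound 1 remains a limit and not a number, so the true size of its step to compound 4 is also open: the limit of < 25 mL/min/kg in this assay, at which 1 of the 4 values shown sits.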